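Replacing the chain hydroxy of compound 1

The source may hold more compounds than are shown below. What is called first, only, known or untested is meant among the compounds shown, and "the series" means these compounds.

compound 1 `C/N=C(/S)[C@@]1(c2cccnc2)CCCC[C@@H]1CCO` — 1700 nM
compound 2 `C/N=C(/S)[C@@]1(c2cccnc2)CCCC[C@@H]1CCNS(=O)(=O)c1ccc([N+](=O)[O-])cc1` — 300 nM
compound 3 `CNC(=S)[C@@]1(c2cccnc2)CCCC[C@@H]1CCNS(=O)(=O)c1ccc(OC)cc1` — 300 nM

In a functional assay (aorta) with Rattus norvegicus as the target (on this read-out lower numbers stand for stronger inhibition and higher numbers for weaker inhibition), compound 1 gives the highest number of the three; compound 2 and compound 3 each give a lower number, beyond the scatter, and those two values lie within the scatter of each other. Compound 4 `C/N=C(/S)[C@@]1(c2cccnc2)CCCC[C@@H]1CCN1C(=O)COCC1=O` is not yet measured. It differs from compound 1 in one place: 3,5-dioxomorpholin-4-yl in place of hydroxy on a saturated chain carbon, two bonds along the chain from a saturated ring carbon. For the measured compounds named here, no step between measured compounds that differ in one place is available, so the expectation rests only on compound 2 and compound 3, where a larger group on the same chain goes with a lower number. For compound 4 a lowering step is expected in this assay, a 3.4-fold lower number from compound 1 to compound 4 (0.53 log units; beyond the scatter), probably beyond the scatter. The estimate for compound 4 is 500 nM with a range from 150 nM to 1500 nM.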

Compound 4, concentration for 90% inhibition: 100 nM
Compound 4: the middle estimate sits 5.0-fold (0.70 log units) above what was measured; the measured number lies below the stated range.
By their numbers in this assay, from the lowest: compound 4; then compounds 2 and 3 (each within the scatter of the next); then compound 1.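

In this assay the exchange of hydroxy for 3,5-dioxomorpholin-4-yl on this chain gives a 17-fold lower number from compound 1 to compound 4 (1.23 log units; beyond the scatter) and so a large step at this position. The entering group carries no hydrogen-bond donor, so a low number here does not require a donor at the chain end. No measurement on hand explains the size of this step.

Open, as far as these compounds go, is whether the ring as a whole or its carbonyls account for the step. An open-chain amide, an amine or a carboxylic acid at this place would test that.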